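The compounds below may be only part of what the source reports. "The series", "measured", "known", "first", "only" and "open" are said of these compounds alone.

Compound 1 `COc1ccc(-c2cc3ccccc3nc2/C=C/C(=O)c2ccccc2)cc1`: in a functional assay on H184B5F5/M10 cells (Homo sapiens) for antiproliferative activity, read by XTT assay, with a stated time of 72 h (on this read-out lower numbers stand for stronger inhibition and higher numbers for weaker inhibition), compound 1 gives 8560 nM.
Compound 2 `COc1ccc(-c2cc3ccccc3nc2/C=C/C(=O)c2cccs2)cc1`: in this assay compound 2 gives 7030 nM.
Compound 3 `COc1ccc(-c2cc3ccccc3nc2/C=C/C(=O)c2sccc2N)cc1`: in this assay compound 3 gives > 10000 nM, which is a limit of the assay and not a number.

Compound 3 therefore stands apart from the other two only in that no number is known for it. The steps leading to it, an at least 1.1-fold higher number from compound 1 to compound 3 (0.06 log units; that floor lies within the scatter) and an at least 1.4-fold higher number from compound 2 to compound 3 (0.15 log units; that floor lies within the scatter), rest on that floor and lie within the scatter, as does a 1.2-fold lower number from compound 1 to compound 2 (0.09 log units; within the scatter). In short, the three exchanges of the ring on the carbonyl carbon seen so far have not moved the read-out beyond the scatter; the limit of > 10000 nM in this assay, at which 1 of the 3 values shown sits, is the one place where the data stop short.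

Compound 4 `COc1ccc(-c2cc3ccccc3nc2/C=C/C(=O)c2c[nH]c3ccccc23)cc1` is not yet measured. The change is 1H-indol-3-yl in place of 3-aminothiophen-2-yl on a carbonyl carbon, again a swap of the ring at the carbonyl carbon whose other neighbour is a double-bonded chain carbon. The three measured steps all bear on it, and all were within the scatter, so no step beyond the scatter is expected in this assay, in either direction. Compound 4 is accordingly estimated at 8000 nM, with a range from 3000 nM to 25000 nM. For compound 4 the expected step is an at least 1.2-fold lower number from compound 3 to compound 4 (0.09 log units; that floor lies within the scatter).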

Compound 4, half-maximal inhibitory concentration: > 10000 nM
Compound 4 gave a limit, no number; the forecaster's own chance of this, stated with the estimate: 35%; at least 1.2-fold (0.09 log units) between middle value and limit.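

In this assay compound 4 gives > 10000 nM, which is a limit of the assay and not a number, so the six-membered aromatic ring of carbon only that 1H-indol-3-yl brings to this place on a carbonyl carbon yields no measurable potency here. Set against the two compounds with numbers, the readable steps are an at least 1.4-fold higher number from compound 2 to compound 4 (0.15 log units; that floor lies within the scatter) and an at least 1.1-fold higher number from compound 1 to compound 4 (0.06 log units; that floor lies within the scatter), both floors within the scatter, so neither shows a real loss, while the step between the two limits cannot be read. The data now stop short at two different rings on the carbonyl carbon, 3-aminothiophen-2-yl and 1H-indol-3-yl: the limit of > 10000 nM in this assay, at which 2 of the 4 values shown sit.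

How far compound 3 and compound 4 lie beyond the limit remains open, so these two rings cannot be ranked, and none of the rings shown at this place gives a step beyond the scatter. Also open, going by these compounds, is whether an amine or a carboxylic acid carried on the phenyl ring of compound 1, or a longer chain in place of that ring, would move the read-out beyond the scatter in this assay.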